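Adding an Amino Group Beside the Methoxy of Compound 1

The source may hold more compounds than are shown below. What is called first, only, known or untested is meant among the compounds shown, and "the series" means these compounds.

The compounds here share one core, a benzene ring carrying three methoxy groups, joined through a nitrogen to a benzyl arm. Compound 1 `COc1ccc(CNc2cc(OC)c(OC)c(OC)c2)cc1` carries a methoxy on that arm, and in a functional assay on KYSE-450 cells (Homo sapiens) for inhibition, read by MTT assay, with a stated time of 48 h (a higher number here means a weaker inhibitor, a lower number a stronger inhibitor), compound 1 gives 4890 nM, the highest of the two plain numbers recorded. Compound 2 `COc1ccc(CN(C(=O)C[Se]C#N)c2cc(OC)c(OC)c(OC)c2)cc1O` differs in more than one place and in this assay gives 280 nM. Compound 3 `COc1cc(NCc2ccccc2)cc(OC)c1OC` has a bare benzyl arm; for compound 3 this assay reports only a limit, > 80000 nM, not a number. Because of the limit of > 80000 nM in this assay, at which 1 of the 3 values shown sits, the step of an at least 16-fold higher number from compound 1 to compound 3 (1.21 log units; beyond the scatter) is known only as a minimum, but it shows that stripping the methoxy weakens the compound greatly, so the substitution on the arm matters.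

Compound 4 `COc1ccc(CNc2cc(OC)c(OC)c(OC)c2)cc1N` is the next step: amino in place of hydrogen on an aromatic carbon. Among the measured compounds shown here, no measured step matches this exact change. For the measured compounds named here, the one relevant step, from compound 1 to compound 3, shows that the arm is sensitive to what it carries, and compound 2, with an oxygen group in the same place, gives a lower number. A modest step to a lower number is therefore expected in this assay, a 2.4-fold lower number from compound 1 to compound 4 (0.39 log units; beyond the scatter). Compound 4 is estimated at 2000 nM, within a range of 500 nM to 8000 nM.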

Compound 4, half-maximal inhibitory concentration: 2210 nM
Compound 4: middle estimate off by 1.1-fold (0.04 log units), on the low side; the measured number falls inside the stated range.
By their numbers in this assay, from the lowest: compound 2; then compound 4; then compound 1. At a limit, above all of these: compound 3.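

In this assay the amino group gives a 2.2-fold lower number from compound 1 to compound 4 (0.34 log units; beyond the scatter) and so this step is modest, though beyond the usual scatter. The earlier step on the arm took a methoxy group away, whereas this one adds a group to an aromatic carbon ortho to a methoxy group, and it shows that this place tolerates a new group with no loss of inhibition: the number moves down, not up. What the amino group does there to produce this small gain cannot be told from the values shown, and nothing measured here explains it.

Going by these compounds, it remains open whether the gain is particular to the amino group or would also appear with another small group at this place, such as a fluorine, a methyl group or a methylamino group. It is also open whether the methoxy group is needed for the step, as every compound shown with the amino group also carries that methoxy group.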